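The source may report more compounds than this note shows. Statements on the series, on what has been measured and on what is new or still open speak of the compounds shown alone.

- compound 1 `CC1=C(CC(=O)N(C)CCN(C)C)c2cc(F)ccc2/C1=C\c1nc2ccccc2s1`: 2020 nM
- compound 2 `CC1=C(CC(=O)NCCN(C)C)c2cc(F)ccc2/C1=C\c1ccc(S(C)(=O)=O)cc1`: 12700 nM

In a functional assay on HT-29 cells (Homo sapiens) for inhibition, read by CellTiter-Glo, with a stated time of 72 h (on this read-out lower numbers stand for higher toxicity in this test and higher numbers for lower toxicity in this test), compound 1, at 2020 nM, holds the lower of the two numbers, and compound 2, at 12700 nM, lies beyond the usual scatter from it. Compound 3 `CC1=C(CC(=O)N2CCN(c3ccncc3)CC2)c2cc(F)ccc2/C1=C\c1nc2ccccc2s1` is not yet measured. It keeps the core of compound 1 and carries this change: 4-(pyridin-4-yl)piperazin-1-yl in place of (2-(dimethylamino)ethyl)(methyl)amino on a carbonyl carbon. The 4-(pyridin-4-yl)piperazin-1-yl group thus stands in place of (2-(dimethylamino)ethyl)(methyl)amino on a carbonyl carbon. For the measured compounds named here, no measured pair differs in one place only, so the expectation rests on the value of compound 1 and the structural change alone. A modest move to a higher number in this assay is expected, and the estimated 1.5-fold higher number from compound 1 to compound 3 (0.17 log units; within the scatter) may not clear the scatter. For compound 3 the estimated value is 3000 nM, with an expected range from 900 nM to 10000 nM.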

Compound 3, half-maximal cytotoxic concentration: 5250 nM
Compound 3: middle estimate off by 1.8-fold (0.24 log units), on the low side; measured number inside the range.
By their numbers in this assay, from the lowest: compound 1; then compound 3; then compound 2.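

Placing 4-(pyridin-4-yl)piperazin-1-yl on the carbonyl carbon in place of (2-(dimethylamino)ethyl)(methyl)amino gives a 2.6-fold higher number from compound 1 to compound 3 (0.41 log units; beyond the scatter) in this assay, the first single-place reading in the series. The substituent on this carbonyl carbon therefore moves the number beyond the scatter, with the higher number standing for lower toxicity in this test, and the open chain can be replaced by a group with two rings. No measured property of these groups bears on the step, so its cause stays unassigned.

Whether the piperazine ring alone or the attached pyridine ring accounts for the step remains open, and a 4-methylpiperazin-1-yl group or a morpholin-4-yl group at this place would separate the two. Also open, on these data alone, is whether the same change gives a similar step on the core of compound 2.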